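Replacing the cyclobutyl group of compound 3

The source may hold more compounds than are shown below. What is called first, only, known or untested is meant among the compounds shown, and "the series" means these compounds.

Compound 1 `CC(C)CCn1nc(-c2cccs2)c(O)c(C2=NS(=O)(=O)c3cc(N(C(C)C)S(C)(=O)=O)ccc3N2)c1=O` gives "not determined" (no result reported)
Compound 2 `CS(=O)(=O)Nc1ccc2c(c1)S(=O)(=O)N=C(c1c(O)c(-c3ccc(Cl)s3)nn(CCC3CC3)c1=O)N2` gives > 33000 nM (a limit)
Compound 3 `CC(C)CCn1nc(C2CCC2)c(O)c(C2=NS(=O)(=O)c3cc(NS(C)(=O)=O)ccc3N2)c1=O` gives > 33000 nM (a limit)

Compound 3 gives > 33000 nM in an ADME assay on Huh-7 cells (Homo sapiens) for cytotoxicity, with a stated time of 72 h (on this read-out lower numbers stand for higher toxicity in this test and higher numbers for lower toxicity in this test), and this is a limit of the assay, not a number. Compound 2 gives > 33000 nM and this too is only a limit. Compound 1 has the entry "not determined" (no result reported) and so offers no comparison. Taken together, the data show the limit of > 33000 nM in this assay, at which 2 of the 3 values shown sit, and give no exact value for compound 3.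

Compound 4 `C/C(=C\c1nn(CCC(C)C)c(=O)c(C2=NS(=O)(=O)c3cc(NS(C)(=O)=O)ccc3N2)c1O)C(F)(F)F` keeps the shared core but carries 2-(trifluoromethyl)prop-1-en-1-yl in place of cyclobutyl on an aromatic carbon, a change counted in full as 2-(trifluoromethyl)prop-1-en-1-yl in place of cyclobutyl on an aromatic carbon here.

In this assay, going by the values given here, no measured step shows what such a swap does, so the expectation rests on compound 3 and its limit > 33000 nM alone. No change beyond the usual scatter is expected in either direction, and the estimated a number no higher from compound 3 to compound 4 (the limit leaves the size open) reflects that. For compound 4 the expected value is 33000 nM with an estimated range from 14000 nM to 66000 nM and another report as a limit is likely.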

Compound 4, half-maximal cytotoxic concentration: > 33000 nM
Compound 4 gave a limit, no number (the forecaster's own chance of this, stated with the estimate: 85%); the middle value lies on the limit itself.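

No step can be read from compound 3 to compound 4, because both results in this assay are limits rather than numbers: the limit of > 33000 nM in this assay, at which 3 of the 4 values shown sit.

The compounds shown leave open what exact value any of them has in this assay, and whether swapping cyclobutyl for 2-(trifluoromethyl)prop-1-en-1-yl changes it at all.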